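The compounds below may be only part of what the source reports. "The series", "measured", "known", "first", "only" and "open" are said of these compounds alone.

- compound 1 `CCCCNC(=O)COc1ccc(C(=O)c2c(CCCC)oc3ccccc23)cc1` gives 22800 nM
- compound 2 `CCCCNC(=O)CCCOc1ccc(C(=O)c2c(CCCC)oc3ccccc23)cc1` gives 24600 nM
- compound 3 `CCCCc1oc2ccccc2c1C(=O)c1ccc(OCCCC(=O)NCc2ccccc2)cc1` is not yet measured

Among the compounds with values here, in a functional assay on U-937 cells (Homo sapiens) for antiproliferative activity, read by MTT assay, with a stated time of 24 h (on this read-out higher numbers stand for weaker inhibition and lower numbers for stronger inhibition), compound 2 at 24600 nM stands level with compound 1, the only other measured compound. Going to compound 3 brings phenyl in place of propyl on a saturated chain carbon bound to an amide-type nitrogen in words, phenyl in place of propyl on a saturated chain carbon bound to an amide-type nitrogen. Within the data shown here, the one measured step, a 1.1-fold higher number from compound 1 to compound 2 (0.03 log units; within the scatter) in size, changes a different place and bears only indirectly. Among the measured compounds shown here, no measured step covers this change, so the range stays wide. No shift beyond the scatter is expected in this assay for now. The expected step is a 1.2-fold lower number from compound 2 to compound 3 (0.09 log units; within the scatter) on this estimate. Compound 3 is expected at 20000 nM with an estimated range from 8000 nM to 50000 nM in this assay.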

Compound 3, half-maximal inhibitory concentration: 15800 nM
Beside the measured number, compound 3's estimate is 1.3-fold (0.10 log units) above it; the range from low to high includes it.
By their numbers in this assay, from the lowest: compounds 3, 1 and 2 (each within the scatter of the next).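

In this assay, within the data shown here, the step of a 1.6-fold lower number from compound 2 to compound 3 (0.19 log units; within the scatter) is the only measured change on the amide-nitrogen side of the series, since the earlier step altered only the chain on the oxygen. This position therefore accepts phenyl in place of propyl, that is benzylcarbamoyl for butylcarbamoyl, without a shift beyond the scatter. No supporting data bear on this result.

Still open, going by these compounds, is whether an amine or a carboxylic acid at this position would move the number beyond the scatter. A longer chain between the phenyl and the amide nitrogen is equally untested here.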